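The source may hold more compounds than are shown below. What is called first, only, known or untested is meant among the compounds shown, and "the series" means these compounds.

In a functional assay on DU-145 cells (Homo sapiens) for cytotoxicity, read by MTT assay (a lower number here means a stronger inhibitor, a higher number a weaker inhibitor), two compounds with a shared core have been measured so far. Compound 1 `COCCO[C@H](CC=C(C)C)C1=CC(=O)c2c(O)ccc(O)c2C1=O` gives 43200 nM, and compound 2 `CC(C)=CC[C@@H](OC(=O)CC(C)(O)C(C)C)C1=CC(=O)c2c(O)ccc(O)c2C1=O` gives 16900 nM, the lower of the two numbers and therefore the stronger result. The next compound, compound 3 `CC(=O)OC(C)CO[C@H](CC=C(C)C)C1=CC(=O)c2c(O)ccc(O)c2C1=O`, keeps the core and has 2-acetoxypropyl in place of (2-hydroxy-2,3-dimethylbutyl)carbonyl on an oxygen on a saturated carbon.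

Within the data shown here, only one measured step bears on this change: a 2.6-fold lower number from compound 1 to compound 2 (0.41 log units; beyond the scatter), a modest difference that involves the same oxygen. In that step, (2-hydroxy-2,3-dimethylbutyl)carbonyl takes the place of 2-methoxyethyl. The 2-acetoxypropyl of compound 3 resembles that 2-methoxyethyl in not being attached through a carbonyl, so part of the step may be reversed. A single step is thin evidence, and 2-acetoxypropyl is not the same group as 2-methoxyethyl, so a modest rise in this assay is the most that can reasonably be expected. The expected change is a 1.8-fold higher number from compound 2 to compound 3 (0.25 log units; within the scatter). The estimated value for compound 3 is 30000 nM, with an expected range of 12000 nM to 70000 nM.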

Compound 3, half-maximal inhibitory concentration: 16600 nM
Estimate against measurement, compound 3: 1.8-fold (0.26 log units) above; the range from low to high includes it.
By their numbers in this assay, from the lowest: compounds 3 and 2 (each within the scatter of the next); then compound 1.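

In this assay, two quite different groups on the oxygen on a saturated carbon give no readable difference, with a 1.0-fold lower number from compound 2 to compound 3 (0.01 log units; within the scatter), so a link through a carbonyl is not needed to reach this level. The hydrogen-bond donor of (2-hydroxy-2,3-dimethylbutyl)carbonyl is not needed either, as 2-acetoxypropyl has none. Compound 1 and compound 3 are both attached without that carbonyl, yet 1-acetoxyethyl in place of methoxymethyl gives a 2.6-fold lower number from compound 1 to compound 3 (0.42 log units; beyond the scatter), a modest step showing that the far part of the chain can shift the number even when the link stays the same. Nothing measured here explains why these groups behave this way.

The compounds shown leave open whether the acetyl part of 2-acetoxypropyl matters, which a plain 2-hydroxypropyl on the same oxygen would help to settle. They also leave open how this position responds to a longer chain, or to a chain ending in an amine or a carboxylic acid.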